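Series notes: seven-membered ring amine substitution and cytotoxicity

The compounds below may be only part of what the source reports. "The series", "measured", "known", "first", "only" and "open" are said of these compounds alone.

Compound 1 `O=C(CCN1CCCCC1)N1CCC2(N3CCCC3)CC(c3ccccc3)C1C(c1ccccc1)C2` gives 108000 nM in an ADME assay on L6 cells (Rattus norvegicus) for cytotoxicity; a lower number here means a stronger inhibitor, a higher number a weaker inhibitor. Compound 2 `CCN1CCN(CCN2CCC3(N4CCCC4)CC(c4ccccc4)C2C(c2ccccc2)C3)CC1` gives 53600 nM in this assay. Compound 3 `CN(C)C12CCN(C(=O)CCN3CCCCC3)C(C(c3ccccc3)C1)C(c1ccccc1)C2` gives 128000 nM in this assay. The core of compound 3 differs from that of compound 1 by dimethylamino in place of pyrrolidin-1-yl on a saturated ring carbon, which made the step of a 1.2-fold higher number from compound 1 to compound 3 (0.07 log units; within the scatter). Compound 2 differs from compound 1 by 2-(4-ethylpiperazin-1-yl)ethyl in place of (2-(piperidin-1-yl)ethyl)carbonyl on an amine nitrogen in a ring, which made the step of a 2.0-fold lower number from compound 1 to compound 2 (0.30 log units; within the scatter). Compound 4 `CCN1CCN(CCN2CCC3(N(C)C)CC(c4ccccc4)C2C(c2ccccc2)C3)CC1` is not yet measured in this assay; it differs from compound 3 by 2-(4-ethylpiperazin-1-yl)ethyl in place of (2-(piperidin-1-yl)ethyl)carbonyl on an amine nitrogen in a ring. For the measured compounds named here, this is the same kind of change as the one from compound 1 to compound 2, though around the place it is three ring bonds from the ring atom that bears a dimethylamino group rather than from the ring atom that bears a pyrrolidin-1-yl group. Compound 3 against compound 2 shows the highest and lowest numbers of the three. For compound 4 the step of a 2.0-fold lower number from compound 3 to compound 4 (0.30 log units; within the scatter) is expected in this assay, resting on compound 1 to compound 2 because of a 2.0-fold lower number from compound 1 to compound 2 (0.30 log units; within the scatter). Compound 4 is therefore estimated at 64000 nM, between 30000 nM and 140000 nM.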

Compound 4, half-maximal inhibitory concentration: 58000 nM
The estimate for compound 4 lay 1.1-fold (0.04 log units) above the measured number; the measured number falls inside the stated range.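

In this assay, 2-(4-ethylpiperazin-1-yl)ethyl in place of (2-(piperidin-1-yl)ethyl)carbonyl gives a 2.2-fold lower number from compound 3 to compound 4 (0.34 log units; beyond the scatter), and this change carries from the pyrrolidin-1-yl core to the dimethylamino core without a difference beyond the scatter: the same change on two cores in this assay, a 2.0-fold lower number (0.30 log units; within the scatter) from compound 1 to compound 2 and a 2.2-fold lower number (0.34 log units; beyond the scatter) from compound 3 to compound 4, 1.1-fold (0.04 log units) apart, within the scatter of two such steps. Dimethylamino in place of pyrrolidin-1-yl gives a 1.1-fold higher number from compound 2 to compound 4 (0.03 log units; within the scatter), and it also reads the same with either side chain: the same change on two cores in this assay, a 1.2-fold higher number (0.07 log units; within the scatter) from compound 1 to compound 3 and a 1.1-fold higher number (0.03 log units; within the scatter) from compound 2 to compound 4, 1.1-fold (0.04 log units) apart, within the scatter of two such steps. Across these four compounds the two changes therefore behave as independent, but this does not show that they would do so on other cores or in another assay, and the side-chain step, which is small, cannot separate the loss of the carbonyl from the exchange of piperidine for ethylpiperazine.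

Still open, going by these compounds, is whether a piperidin-1-yl or morpholin-4-yl group on the saturated ring carbon would follow the same pattern. Also open, on these data alone, is how a longer chain between the ring nitrogen and the ethylpiperazine would behave.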